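Methoxy in place of amino on the benzoyl of compound 1

This account rests on a few compounds, and the source may have more. Where it says the series, first, only, none or still open, it means among the compounds named here.

Compound 1 `CC(/C=N/Nc1ccc([N+](=O)[O-])cc1)=N\NC(=O)c1ccc(N)cc1` was tested in a functional assay on cells (Splenocyte, Mus musculus, strain BALB/c) for inhibition, read by scintillation counting and thymidine incorporation, with a stated time of 72 h; a lower number here means a stronger inhibitor, a higher number a weaker inhibitor. Compound 1 gives only the limit > 12000 nM, not a number. Compound 2 `CC(/C=N/Nc1ccc([N+](=O)[O-])cc1)=N\NC(=O)c1ccccc1F` likewise gives only the limit > 12000 nM. Compound 3 `CC(/C=N/Nc1ccc([N+](=O)[O-])cc1)=N\NC(=O)c1ccc(C(F)(F)F)cc1` also gives only the limit > 12000 nM. The steps a step that the two limits leave unreadable from compound 1 to compound 2 and a step that the two limits leave unreadable from compound 1 to compound 3 therefore cannot be sized, the reason being (the limit of > 12000 nM in this assay, at which 3 of the 3 values shown sit). Compound 4 `COc1ccc(C(=O)N/N=C(C)/C=N/Nc2ccc([N+](=O)[O-])cc2)cc1` differs from compound 1 by methoxy in place of amino on an aromatic carbon. Neither measured step bears readably on this change, so no direction beyond the scatter can be drawn from them. Compound 4 is expected to remain at the same limit, with an estimated step that the limit leaves unreadable from compound 1 to compound 4. The estimate for compound 4 is 20000 nM, ranging from 8000 nM to 60000 nM.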

Compound 4, half-maximal inhibitory concentration: > 12000 nM
Compound 4 was reported as a limit; the forecaster's own chance of this, stated with the estimate: 80%; the middle value lies beyond the limit too.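

Compound 4, like compound 1, compound 2 and compound 3, gives only a limit, so no step among these compounds can be read: the limit of > 12000 nM in this assay, at which 4 of the 4 values shown sit.

The compounds shown leave open which change to the shared core, if any, would give a measurable value in this assay.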